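The source may report more compounds than this note shows. Statements on the series, on what has been measured and on what is new or still open speak of the compounds shown alone.

Measured compounds:
- Compound 1 `Cc1ccc(OCC(=O)N(Cc2cccs2)c2nccn2C)cc1` — in an assay on HEK293 cells for agonist activity at transient receptor potential cation channel subfamily M member 8 (Homo sapiens), read by fluorescence and calcium flux, with a stated time of 15 min (a higher number here means that more compound is needed for the effect, a lower number that less compound is needed), compound 1 gives 1790 nM
- Compound 2 `Cc1ccc(OCC(=O)N(Cc2cccs2)c2ccn[nH]2)cc1` — in this assay compound 2 gives 0.2 nM

Compound 2 stands at the lowest number of the two measured in this assay; its nearest neighbour is compound 1, and the step of a 9000-fold lower number from compound 1 to compound 2 (3.95 log units; beyond the scatter) separates them. That single step is the only one recorded, and it falls exactly on the position now in question: the group on the amide-type nitrogen that carries the thiophenylmethyl and the carbonyl.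

Compound 3 `Cc1ccc(OCC(=O)N(Cc2cccs2)C2CC2)cc1` has not yet been measured in this assay. It differs from compound 2 as follows: cyclopropyl in place of 1H-pyrazol-5-yl on an amide-type nitrogen. Among the compounds with values here, the one measured step, a 9000-fold lower number from compound 1 to compound 2 (3.95 log units; beyond the scatter), shows that exchanging the ring on this nitrogen can shift the number enormously, so a large step is expected here as well, and since compound 2 already sits at the lowest number, the expected direction is upward, toward a higher number. The step that this expectation means for compound 3 is a 1500-fold higher number from compound 2 to compound 3 (3.18 log units; beyond the scatter). Compound 3 is therefore estimated at 300 nM, within a range from 10 nM to 10000 nM.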

Compound 3, half-maximal effective concentration: 8 nM
For compound 3 the middle estimate is 38-fold (1.57 log units) above the measured one; the measured number lies below the stated range.
By their numbers in this assay, from the lowest: compound 2; then compound 3; then compound 1.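

In this assay the group on this amide-type nitrogen does not have to be aromatic or hold any hetero atom: the one three-membered ring of carbon only still gives a 220-fold lower number from compound 1 to compound 3 (2.35 log units; beyond the scatter) and so places compound 3 far from compound 1 on the low side. The 1H-pyrazol-5-yl nevertheless keeps a clear lead over the cyclopropyl, with a 40-fold higher number from compound 2 to compound 3 (1.60 log units; beyond the scatter) on this exchange, so the position separates three groups into three clearly distinct levels rather than into a simple pair of good and bad. Nothing available explains either step.

The compounds shown leave open whether a ring is needed here at all, since an open chain such as ethyl or isopropyl, or a larger carbon ring such as cyclobutyl, would test that directly. They also leave open what part of the high number of compound 1 belongs to the methyl on its ring and what part to the imidazole itself, a question that a 1H-imidazol-2-yl or a 1-methylpyrazole group on the same nitrogen would separate.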